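Series notes: carboxy replaced by (3-hydroxyazetidin-1-yl)carbonyl

The compounds below may be only part of what the source reports. "The series", "measured", "known", "first", "only" and "open" are said of these compounds alone.

Three members of the series have so far been run in an ADME assay on microsomes from liver (Rattus norvegicus) for metabolic stability, read by LC-MS, using NADPH, with a stated time of 30 min, tested at 0.1 uM, in the presence of a further agent that is not named here; on this read-out lower numbers stand for a less stable compound and higher numbers for a more stable compound. Compound 1 `N#Cc1ccc(-c2cnc(N)c(-c3ccc(N)nc3)n2)cc1` returns only the assay limit, > 90%. Compound 3 `Nc1ccc(-c2cnc(N)c(-c3ccc(N)nc3)n2)cn1` likewise sits at the limit, > 90%. Compound 2 `Nc1ncc(-c2ccc(C(=O)O)cc2)nc1-c1ccc(C(F)(F)F)cc1` also comes back at the limit in this assay, namely > 90%, so compound 2 stands level with the rest of the set shown: the limit of > 90% in this assay, at which 3 of the 3 values shown sit. For the measured compounds named here, no two measured compounds differ in a single place, so no measured step is available to anchor an expectation for a new analogue.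

Compound 4 `Nc1ncc(-c2ccc(C(=O)N3CC(O)C3)cc2)nc1-c1ccc(C(F)(F)F)cc1` is the next entry. It differs from compound 2 as follows: 3-hydroxyazetidin-1-yl in place of hydroxy on a carbonyl carbon. Nothing measured in this assay within this set speaks to such a change, and the working expectation is therefore no shift beyond the scatter, with the result most likely once more reported at the limit. Compound 4 is estimated at 85% in this assay, between 60% and 95%. That estimate means an expected step of a number at least 5 percentage points lower from compound 2 to compound 4 (that floor lies within the scatter), which would lie within the scatter.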

Compound 4, percent of the compound remaining: > 90%
Compound 4 was reported as a limit (the forecaster's own chance of this, stated with the estimate: 55%); middle value at least 5 percentage points from the limit.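

For the compounds shown here, compound 2 and compound 4 are both reported only as limits, and no step between them can be read. The compounds shown leave open whether carboxy to (3-hydroxyazetidin-1-yl)carbonyl shifts the read-out at all in this assay, and the whole set stands as follows: the limit of > 90% in this assay, at which 4 of the 4 values shown sit.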